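The source may hold more compounds than are shown below. What is called first, only, known or untested is meant among the compounds shown, and "the series" means these compounds.

Working notes on the series. Three measured members share the core of compound 1 `Cn1nc(-c2ccc(F)cc2)cc1CO[C@@H]1COc2nc([N+](=O)[O-])cn2C1`; compound 2 `O=[N+]([O-])c1cn2c(n1)OC[C@@H](OCc1cn(-c3ccc(C(F)(F)F)cc3)nn1)C2` carries a trifluoromethyl on an aromatic carbon and compound 3 `N#Cc1ccc(-n2cc(CO[C@@H]3COc4nc([N+](=O)[O-])cn4C3)nn2)cc1` a cyano in its place. In an ADME assay on Vero cells (Chlorocebus sabaeus) for cytotoxicity, with a stated time of 72 h (on this read-out higher numbers stand for weaker inhibition and lower numbers for stronger inhibition), compound 1 gives > 128000 nM, which is a limit of the assay. In this assay compound 2 gives > 128000 nM, again a limit. Compound 3 gives > 128000 nM, also a limit. Compound 3 thus stands at the limit, as do all values shown so far (the limit of > 128000 nM in this assay, at which 3 of the 3 values shown sit). The step that the two limits leave unreadable from compound 2 to compound 3 is not readable, both of its ends being limits.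

Compound 4 `O=[N+]([O-])c1cn2c(n1)OC[C@@H](OCc1cn(-c3ccc(OC(F)(F)F)cc3)nn1)C2` differs from compound 3 by trifluoromethoxy in place of cyano on an aromatic carbon. Going by the values given here, no readable measured step bears on this change; the one step available, cyano in place of trifluoromethyl, is unreadable. Given that every value sits at the limit (the limit of > 128000 nM in this assay, at which 3 of the 3 values shown sit), no shift beyond the scatter is expected, and the step that the limit leaves unreadable from compound 3 to compound 4 is estimated as none. Compound 4 is expected to give 200000 nM, in the range 128000 nM to 600000 nM, most probably reported again only as a limit.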

Compound 4, half-maximal inhibitory concentration: > 128000 nM
Compound 4: only a limit was reported; the forecaster's own chance of this, stated with the estimate: 90%; the middle value is on the limit's open side.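

Going by these compounds alone, compound 4 sits at a limit in this assay, as do compound 2 and compound 3, so no step from either of them to compound 4 can be read: the limit of > 128000 nM in this assay, at which 4 of the 4 values shown sit. The compounds shown leave open how trifluoromethoxy, trifluoromethyl and cyano compare in this assay.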